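A few compounds are considered here, and "the series" means these few. Any claim that something is new, unique, unknown or untested is made for them only; others in the source may bear on it.

Of the compounds shown here, three have been measured in a functional assay on the whole organism (uterus) with Rattus norvegicus as the target, tested at 10 uM; on this read-out higher numbers stand for a weaker effect at the one concentration tested and lower numbers for a stronger effect. Compound 1, `C[C@@H](Nc1nc(O)c2cc(Cl)ccc2n1)C1CCCCC1`, gives 108% in this assay. Compound 2, `C[C@@H](Nc1nc(O)c2cc(Cl)ccc2n1)c1ccccc1`, gives 120%. Compound 3, `Oc1nc(NCC2CCCCC2)nc2ccc(I)cc12`, gives 96.8%, the lowest of the three, and its step to each of the other two lies beyond the scatter.

Compound 1 and compound 2 differ in one place: phenyl in place of cyclohexyl on a saturated chain carbon bound to a nitrogen on an aromatic ring and a saturated chain carbon. This change made a step of a number 12 percentage points higher from compound 1 to compound 2 (beyond the scatter), a shift towards a weaker effect at the concentration tested.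

Compound 4, `Oc1nc(NCc2ccccc2)nc2ccc(I)cc12`, has not yet been measured. It is built from compound 3 by the same kind of change: phenyl in place of cyclohexyl on a saturated chain carbon bound to a nitrogen on an aromatic ring. The place is not the same word for word, since in compound 1 the carbon carrying the ring is bound to a nitrogen on an aromatic ring and a saturated chain carbon, whereas in compound 3 it is bound to a nitrogen on an aromatic ring only. The core of compound 3 also differs from the core of compound 1, and that difference is not broken down here.

On this basis, the step from compound 3 to compound 4 in this assay is expected to be about a number 12.2 percentage points higher from compound 3 to compound 4 (beyond the scatter), because the same kind of change gave a number 12 percentage points higher from compound 1 to compound 2 (beyond the scatter). This rests on a single pair, so the expectation is loose. Compound 4 is therefore estimated to give 109% in this assay, with a range from 96% to 122%.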

Compound 4, a percentage reported as activity, at one concentration (the size of the read-out at that concentration, not a potency): 106%
Estimate against measurement, compound 4: 3 percentage points above; the range from low to high includes it.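

In this assay, putting phenyl in place of cyclohexyl gives a number 9.2 percentage points higher from compound 3 to compound 4 (within the scatter), so on this core the change alone cannot be told apart from the ordinary spread of repeated measurements. Set beside the earlier pair, the step is of a similar size on both cores, which fits the idea that this change carries over from one core to the other: the same change on two cores in this assay, a number 12 percentage points higher (beyond the scatter) from compound 1 to compound 2 and a number 9.2 percentage points higher (within the scatter) from compound 3 to compound 4, 2.8 percentage points apart, within the scatter of two such steps. Among these compounds, this agreement rests on only two pairs, each read at a single concentration, so it does not show that the change would behave the same way on a further core, and it says nothing about why the two steps are alike.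

The compounds shown have only cyclohexyl or phenyl in this place, so it remains open how an amine, a carboxylic acid or a longer chain would read there. The two cores also differ in more than one respect, and the compounds shown do not separate those differences, so how much each contributes to the read-out is still unknown.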